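Compound 4: a Longer Chain Where Isopropyl Stood

A few compounds are considered here, and "the series" means these few. Any claim that something is new, unique, unknown or untested is made for them only; others in the source may bear on it.

Of the compounds shown here, three built on a shared core have been tested in a functional assay on the whole organism (Tail, strain ICR) with Mus musculus as the target, in the tail flick test, with a stated time of 60 min, at a dose of 12.5 umol/kg by the oral route; a higher number here means a stronger effect of the compound at the dose given, a lower number a weaker effect. Compound 1 `O=C(CN(c1nc(Cl)nc2[nH]cnc12)C1CC1)NCC(=O)OCc1ccccc1` gives 23.7%. Compound 2 `N=C(N)NCCC[C@H](NC(=O)CN(c1nc(Cl)nc2[nH]cnc12)C1CC1)C(=O)O` gives 39.8%. Compound 3 `CC(C)[C@H](NC(=O)CN(c1nc(Cl)nc2[nH]cnc12)C1CC1)C(=O)OCc1ccccc1` gives 26.5%, the second highest of the three numbers: compound 1 lies within the scatter of it, whereas compound 2 sits beyond the scatter above it.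

Within the data shown here, only one measured step changes a single place, a number 2.8 percentage points higher from compound 1 to compound 3 (within the scatter), and it stays within the scatter, so placing a small side chain at that carbon did not move the read-out in any trustworthy way.

Among the measured compounds shown here, compound 4 `NCCCC[C@H](NC(=O)CN(c1nc(Cl)nc2[nH]cnc12)C1CC1)C(=O)OCc1ccccc1` differs from compound 3 by one change: 4-aminobutyl in place of isopropyl on a saturated chain carbon bound to an amide-type nitrogen and a carbonyl carbon No measured step exchanges one chain for another at this place, so the earlier step gives only a weak hint that the read-out tolerates a substituent there. The wider gap between compound 3 and compound 2 shows that larger values are reachable in this series, but that pair differs in more than one place and cannot be read as a single step.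

For compound 4 the read-out is expected near 32%, with a plausible range from 18% to 48%. This amounts to an expected step of a number 5.5 percentage points higher from compound 3 to compound 4 (within the scatter), most likely not beyond the scatter.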

Compound 4, a percentage reported as activity, at one dose (the size of the read-out at that dose, not a potency): 30%
The estimate for compound 4 lay 2 percentage points above the measured number; the range from low to high includes it.
By their numbers in this assay, from the lowest: compounds 1, 3, 4 and 2 (each within the scatter of the next, the first and the last beyond it).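

In this assay, putting 4-aminobutyl in place of isopropyl on this saturated chain carbon gives a number 3.5 percentage points higher from compound 3 to compound 4 (within the scatter) and so shows that a longer chain ending in an amine, with 5 heavy atoms where 3 stood, brings no change that can be trusted. Set against plain hydrogen at the same carbon, this chain gives a number 6.3 percentage points higher from compound 1 to compound 4 (within the scatter) and the isopropyl group gives a number 2.8 percentage points higher from compound 1 to compound 3 (within the scatter) so neither side chain separates clearly from hydrogen, even though the two differ widely in size and one carries a nitrogen. Nothing available explains why the read-out stays this flat at this place.

From the compounds shown here alone, whether a chain ending in a carboxylic acid, or a benzyl group, on this carbon would move the read-out beyond the scatter stays open. Going by these compounds, compound 2 differs from compound 4 in more than one place, so that pair cannot be read as a single step, and what the arginine-like chain or the free acid of compound 2 contributes on its own remains unknown.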